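Urea substituent change on a quinolinone substance-P ligand series

The compounds below may be only part of what the source reports. "The series", "measured", "known", "first", "only" and "open" are said of these compounds alone.

Measured so far:
- compound 1 `COc1ccccc1CNC(=O)c1c(-c2ccccc2C)c2ccccc2c(=O)n1C`: 470 nM
- compound 2 `Cc1cc2c(-c3ccccc3)c(NC(=O)N(C)Cc3ccccc3Cl)n(C)c(=O)c2cc1C`: 4.2 nM
- compound 3 `COc1ccccc1CNCc1c(-c2ccccc2)c2cc(C)c(C)cc2c(=O)n1C`: 13 nM

In an assay on IM-9 cells for binding affinity to Substance-P receptor (Homo sapiens) (a lower number here means a stronger inhibitor, a higher number a weaker inhibitor), compound 2 gives 4.2 nM, the lowest of the three numbers. Its nearest neighbour on the numbers is compound 3, whose value in this assay is beyond the scatter; compound 1 lies far further up the scale. Among the measured compounds shown here, compound 1 and compound 3 differ from compound 2 in several places at once, so no single step between measured compounds is available to read off.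

Compound 4 `Cc1cccc(NC(=O)Nc2c(-c3ccccc3)c3cc(C)c(C)cc3c(=O)n2C)c1` is not yet measured. It keeps the core of compound 2 with the urea carbonyl in place and changes only the substituent on that carbonyl carbon: a group of 8 heavy atoms (7 carbon, 1 nitrogen; one six-membered aromatic ring of carbon only) in place of a group of 10 heavy atoms (8 carbon, 1 nitrogen, 1 chlorine; one six-membered aromatic ring of carbon only), on a carbonyl carbon. The entering (3-methylphenyl)amino brings one hydrogen-bond donor where the leaving group had none, and the chlorine is lost.

With no measured step of this kind in the series, the direction is uncertain; the expectation is a moderate loss, since the leaving group belongs to the most potent compound seen. Compound 4 is estimated at 25 nM (range 5 nM to 150 nM), which would mean a step of a 6.0-fold higher number from compound 2 to compound 4 (0.77 log units; beyond the scatter) in this assay.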

Compound 4, half-maximal inhibitory concentration: 840 nM
Estimate against measurement, compound 4: 34-fold (1.53 log units) below; measured number above the stated range.
By their numbers in this assay, from the lowest: compound 2; then compound 3; then compounds 1 and 4 (each within the scatter of the next).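

Among the compounds shown here, replacing the group on the carbonyl carbon with (3-methylphenyl)amino gives a 200-fold higher number from compound 2 to compound 4 (2.30 log units; beyond the scatter) in this assay and is the first single-place change that can be read. The substituent on the urea carbonyl therefore matters greatly here, since the step is large with the shared core and the carbonyl kept. The change is nonetheless compound: it removes the chlorine, adds a hydrogen-bond donor and reduces the group's heavy-atom count, and nothing measured bears on the reason for the step.

Which of these differences accounts for the loss remains open, and a single pair cannot separate them. A benzylamino or N-methyl-N-(3-methylphenyl)amino group on the same carbonyl carbon would test whether the ring link or the added donor tracks with the change.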